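Second Phenyl at the Amide Carbon: Compound 4 Expected

A few compounds are considered here, and "the series" means these few. Any claim that something is new, unique, unknown or untested is made for them only; others in the source may bear on it.

Measured compounds:
compound 1 `Cc1nc(N)sc1CCCN/C(N)=N/C(=O)N[C@H](C)c1ccccc1`, 0.95
compound 2 `Cc1nc(N)sc1CCCN/C(N)=N/C(=O)NC(c1ccccc1)C(C)C`, 1.04
compound 3 `Cc1nc(N)sc1CCCN/C(N)=N/C(=O)NCc1ccco1`, 0.58

In a functional assay on Right cardiac atrium for agonist activity at histamine H2 receptor (Cavia porcellus), with a stated time of 30 min, in the presence of a further agent that is not named here (on this read-out lower numbers stand for smaller maximal responses and higher numbers for larger maximal responses), compound 2 gives 1.04, the top of the three numbers; the gap to compound 1 is within the usual scatter, while compound 3 lies well beyond it. Compound 4 `Cc1nc(N)sc1CCCN/C(N)=N/C(=O)NC(c1ccccc1)c1ccccc1` is unmeasured. Its change from compound 2 is phenyl in place of isopropyl on a saturated chain carbon bound to an amide-type nitrogen and an aromatic carbon. For the measured compounds named here, no measured step swaps isopropyl for phenyl at this carbon. Going by the values given here, the only measured step, a number 0.37 lower from compound 1 to compound 3 (beyond the scatter), removed the phenyl-bearing group and lowered the response greatly, so a phenyl on this carbon goes with a near-full response in compounds 1 and 2. Compound 4 keeps that phenyl and gains a second, so little change beyond the scatter is expected, and the step a number 0.090 lower from compound 2 to compound 4 (within the scatter) is estimated to be small. Compound 4 is therefore expected to give about 0.95 in this assay, between 0.75 and 1.05.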

Compound 4, intrinsic activity: the largest response reached, as a fraction of the reference agonist's: 0.9
Compound 4: middle estimate off by 0.050, on the high side; low and high end bracket the measured number.
By their numbers in this assay, from the lowest: compound 3; then compounds 4, 1 and 2 (each within the scatter of the next, the first and the last beyond it).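

In this assay, for the compounds shown here, replacing isopropyl with phenyl on this saturated chain carbon gives a number 0.14 lower from compound 2 to compound 4 (beyond the scatter), the first direct reading of a swap at this carbon. Going by these compounds alone, it shows that the maximal response depends on more than the one phenyl shared by compound 2 and compound 4, since changing the other group on the carbon also moves it, though only modestly. Compound 4 still gives 0.9, so a second phenyl at this carbon keeps a large share of the reference agonist's response, and nothing available explains the size of this step.

The compounds shown leave open how a saturated ring such as cyclohexyl, or a group carrying an amine or a carboxylic acid, would fare on this carbon. They also leave open whether the same swap would give a similar step on a different core.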